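Shifting a methoxy around a fused core

The source may hold more compounds than are shown below. What is called first, only, known or untested is meant among the compounds shown, and "the series" means these compounds.

Compound 1 `COc1cccc2c1CCCC2CCN1CCN(C2CCCCC2)CC1` gives > 7500 nM in an assay for binding affinity to Adrenergic receptor alpha-1 (Rattus norvegicus) (a lower number here means a stronger inhibitor, a higher number a weaker inhibitor), which is a limit of the assay rather than a number. Compound 2 `c1ccc2c(c1)CCCC2CCCN1CCN(C2CCCCC2)CC1` stands at > 7500 nM in this assay, again a limit. Compound 3 `COc1ccc2c(c1)CCCC2CCCN1CCN(C2CCCCC2)CC1` gives > 7500 nM in this assay, also a limit. For the measured compounds named here, the one step that joins two measured compounds, a step that the two limits leave unreadable from compound 2 to compound 3, therefore cannot be read, because the limit of > 7500 nM in this assay, at which 3 of the 3 values shown sit, holds every value shown.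

Compound 4 `COc1ccc2c(c1)C(CCCN1CCN(C3CCCCC3)CC1)CCC2` differs from compound 2 by methoxy in place of hydrogen on an aromatic carbon. Going by the values given here, the only measured step that bears on this change is a step that the two limits leave unreadable from compound 2 to compound 3, which added the same group to compound 2 and left the read-out at the limit; its size is not readable. Among the compounds with values here, no measured step thus gives a direction or a size for the move from compound 2 to compound 4 in this assay, and nothing in the data points to a value on the measurable side of the limit. Compound 4 is accordingly expected to give 15000 nM, within 5000 nM to 60000 nM. The step this implies, a step that the limit leaves unreadable from compound 2 to compound 4, is likewise an expectation and not a measurement.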

Compound 4, inhibition constant: > 7500 nM
Compound 4 gave a limit, no number (the forecaster's own chance of this, stated with the estimate: 80%); the middle value lies beyond the limit too.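

No new step can be read from compound 4, which, like compound 2, gives only a limit and no number, so the step between them stays unreadable: the limit of > 7500 nM in this assay, at which 4 of the 4 values shown sit.

The compounds shown leave open whether the methoxy, wherever it sits on the shared core, has any effect at all in this assay.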